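Hydrazone aryl variation in a pyrimidine dione series

The compounds below may be only part of what the source reports. "The series", "measured", "known", "first", "only" and "open" are said of these compounds alone.

Measured compounds in a functional assay on PC-3 cells (Homo sapiens) for antiproliferative activity, read by MTT assay; on this read-out higher numbers stand for weaker inhibition and lower numbers for stronger inhibition:
- compound 1 `Cn1c(=O)c(=O)n(C2CCCC2)c2nc(N/N=C/c3ccc(O)c(F)c3)ncc21`: 85200 nM
- compound 2 `COc1cccc(/C=N/Nc2ncc3c(n2)n(C2CCCC2)c(=O)c(=O)n3C)c1`: 20700 nM
- compound 3 `COc1ccc(/C=N/Nc2ncc3c(n2)n(C2CCCC2)c(=O)c(=O)n3C)cc1`: 26300 nM

Compound 3 sits second highest of the three numbers in this assay; its nearest neighbour is compound 2, a 1.3-fold higher number from compound 2 to compound 3 (0.10 log units; within the scatter), and the furthest is compound 1, a 3.2-fold lower number from compound 1 to compound 3 (0.51 log units; beyond the scatter). Compound 4 `Cn1c(=O)c(=O)n(C2CCCC2)c2nc(N/N=C/c3cccc([N+](=O)[O-])c3)ncc21` carries 3-nitrophenyl in place of 4-methoxyphenyl on a carbon with a double bond to nitrogen. Within the data shown here, no measured step replaces a methoxyphenyl with a nitrophenyl, so only the aryl steps already seen bear on it: a 4.1-fold lower number from compound 1 to compound 2 (0.61 log units; beyond the scatter) and a 1.3-fold higher number from compound 2 to compound 3 (0.10 log units; within the scatter), which together show this position tolerating aryl changes with modest or no shift. Compound 4 is therefore expected to stay near compound 3, with a 1.1-fold lower number from compound 3 to compound 4 (0.02 log units; within the scatter), and is estimated at 25000 nM, ranging from 8000 nM to 80000 nM.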

Compound 4, half-maximal inhibitory concentration: 20300 nM
Beside the measured number, compound 4's estimate is 1.2-fold (0.09 log units) above it; the measured number falls inside the stated range.
By their numbers in this assay, from the lowest: compounds 4, 2 and 3 (each within the scatter of the next); then compound 1.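

In this assay, nitro in place of methoxy on an aromatic carbon leaves the number level (a 1.0-fold lower number from compound 2 to compound 4 (0.01 log units; within the scatter)), and the change from 4-methoxyphenyl to 3-nitrophenyl does the same (a 1.3-fold lower number from compound 3 to compound 4 (0.11 log units; within the scatter)). Compound 1 now stands apart from all three other compounds, with the third step beyond the scatter (a 4.2-fold lower number from compound 1 to compound 4 (0.62 log units; beyond the scatter)). No evidence at hand explains this grouping.

Open, from the compounds shown here alone, is whether an amine or a carboxylic acid on the aryl ring would shift the number. Also open, going by these compounds, is whether the hydroxy or the fluoro group of compound 1 goes with its separation.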